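Swapping the sulfamoylphenyl position on a sulfamoyl-anilino thiazolidinone core

A few compounds are considered here, and "the series" means these few. Any claim that something is new, unique, unknown or untested is made for them only; others in the source may bear on it.

The measured compounds and their values in a functional assay on Caco-2 cells (Homo sapiens) for antiproliferative activity, read by MTT assay; on this read-out higher numbers stand for weaker inhibition and lower numbers for stronger inhibition:

Compound 1, `NS(=O)(=O)c1ccc(/N=C2\NC(=O)/C(=C3/C(=O)Nc4ccc([N+](=O)[O-])cc43)S2)cc1`, gives 13800 nM.
Compound 2, `NS(=O)(=O)c1cccc(/N=C2\NC(=O)/C(=C3/C(=O)Nc4ccc([N+](=O)[O-])cc43)S2)c1`, gives 20600 nM.
Compound 3, `NS(=O)(=O)c1ccc(/N=C2\NC(=O)/C(=C3/C(=O)N(Cc4ccccc4)c4ccccc43)S2)cc1`, gives only a limit of the assay, > 200000 nM.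

Compounds 1 and 2 share one core and differ in a single place: 3-sulfamoylphenyl in place of 4-sulfamoylphenyl on a double-bonded nitrogen. This change produced a 1.5-fold higher number from compound 1 to compound 2 (0.17 log units; within the scatter), so the two compounds cannot be told apart on this read-out. Compound 3 carries a different core; how its core differs from that of compound 1 is not broken down here. For compound 3 the result is a limit rather than a number, as shown by the limit of > 200000 nM in this assay, at which 1 of the 3 values shown sits.

Compound 4, `NS(=O)(=O)c1cccc(/N=C2\NC(=O)/C(=C3/C(=O)N(Cc4ccccc4)c4ccccc43)S2)c1`, stands to compound 3 exactly as compound 2 stands to compound 1: 3-sulfamoylphenyl in place of 4-sulfamoylphenyl on a double-bonded nitrogen. The surroundings of the change are the same in both pairs, so it is the same change made on a different core.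

From the step seen between compound 1 and compound 2, a 1.5-fold higher number from compound 1 to compound 2 (0.17 log units; within the scatter), the change is expected to move compound 4 little, giving an estimated step that the limit leaves unreadable from compound 3 to compound 4. Since compound 3 itself sits at the limit, > 200000 nM, compound 4 is expected to remain at or beyond that limit as well. The estimate for compound 4 in this assay is 300000 nM, with an expected range from 120000 nM to 1000000 nM.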

Compound 4, half-maximal inhibitory concentration: 103000 nM
Beside the measured number, compound 4's estimate is 2.9-fold (0.46 log units) above it, outside the stated range (below it).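

In this assay, as far as these compounds go, putting 3-sulfamoylphenyl in place of 4-sulfamoylphenyl on the double-bonded nitrogen of the second core gave an at least 1.9-fold lower number from compound 3 to compound 4 (0.28 log units; that floor lies within the scatter), and that figure is only a floor, so the full size of the step on this core stays unknown. The same swap therefore does not carry from one core to the other as a fixed shift, even though it looked negligible on the core of compound 1: the same change on two cores in this assay, a 1.5-fold higher number (0.17 log units; within the scatter) from compound 1 to compound 2 and an at least 1.9-fold lower number (0.28 log units; that floor lies within the scatter) from compound 3 to compound 4, at least 2.8-fold (0.46 log units) apart, beyond the scatter of two such steps Compound 3 gives > 200000 nM, which is a limit of the assay and not a number, and two cores alone show neither what sets the gap between the steps nor how the swap would behave on a third core.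

The compounds shown leave open which part of the difference between the two cores matters, as none of them carries the nitro group without the core of compound 1 or the benzyl group without the core of compound 3. Also open, from the compounds shown here alone, is whether a carboxylic acid or an amine in place of the sulfamoyl group would respond to the same swap on either core.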